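The compounds below may be only part of what the source reports. "The series", "measured", "known", "first", "only" and "open" are said of these compounds alone.

Measured so far:
compound 1, `Fc1ccccc1-c1ccc2[nH]c(C3=NOC4(CCCCC4)C3)nc2c1` – 2.9 nM
compound 2, `Fc1cc(-c2ccccc2C(F)(F)F)cc2nc(C3=NOC4(CCCCC4)C3)[nH]c12` – 2.2 nM

Both compounds were tested in a functional assay on HEK293 cells for antagonist activity at transient receptor potential M8 protein (Canis lupus familiaris), read by FLIPR and calcium flux; on this read-out lower numbers stand for stronger inhibition and higher numbers for weaker inhibition. Compound 1 gives 2.9 nM and compound 2 gives 2.2 nM. Compound 2 shows the smaller of the two numbers, but its gap to compound 1 lies within the usual scatter of repeated measurements, so the two cannot be told apart on this evidence.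

Compound 3, `FC(F)(F)c1ccccc1-c1cc(Br)c2[nH]c(C3=NOC4(CCCCC4)C3)nc2c1`, differs from compound 2 in a single place: bromo in place of fluoro on an aromatic carbon. Within the data shown here, no pair of measured compounds shows the effect of this kind of exchange, so there is no earlier step to lean on; one halogen simply replaces another at the same place. The step of a 1.1-fold higher number from compound 2 to compound 3 (0.06 log units; within the scatter) is therefore expected to stay within the scatter, with no clear direction. Compound 3 is estimated at 2.5 nM, with a likely range from 0.8 nM to 8 nM.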

Compound 3, half-maximal inhibitory concentration: 2.7 nM
Compound 3: middle estimate off by 1.1-fold (0.03 log units), on the low side; low and high end bracket the measured number.
By their numbers in this assay, from the lowest: compounds 2, 3 and 1 (each within the scatter of the next).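

Putting bromo in place of fluoro on this aromatic carbon, ortho to a fused ring, gives a 1.2-fold higher number from compound 2 to compound 3 (0.09 log units; within the scatter) in this assay and so leaves the two compounds indistinguishable. Among these compounds, this is the first view of a change at this position, and it shows that the read-out tolerates either a fluorine atom or the larger bromine atom here, with inhibition in the same low range. Nothing at hand explains why these two halogens read alike.

The compounds shown cover only these two halogens at this position, so it remains open whether the same tolerance would hold for an amine, a methoxy group or a carboxylic acid. A longer chain, such as a propyl group, is equally untested in what is shown here.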